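The source may hold more compounds than are shown below. What is called first, only, known or untested is meant among the compounds shown, and "the series" means these compounds.

Compounds measured so far:
- compound 1 `CCn1c(-c2ccc(OCc3c(-c4c(Cl)cccc4Cl)noc3C(C)C)cc2)nc2ccc(C(=O)O)cc21` — 5760 nM
- compound 2 `CC(C)c1onc(-c2c(Cl)cccc2Cl)c1COc1ccc(-c2nc3ccc(C(=O)O)cc3n2CC(C)(C)C)cc1` — 861 nM
- compound 3 `CCC(CC)n1c(-c2ccc(OCc3c(-c4c(Cl)cccc4Cl)noc3C(C)C)cc2F)nc2ccc(C(=O)O)cc21` — > 10000 nM

All three share the same core and were tested in an assay on HEK-293T cells for antagonist activity at vitamin D3 receptor (Homo sapiens), read by a luciferase reporter, with a stated time of 24 h; a lower number here means a stronger inhibitor, a higher number a weaker inhibitor. Compound 1 gives 5760 nM. Compound 2 gives 861 nM, the lowest of the two plain numbers. The value of compound 3 is not a number but a limit of the assay, > 10000 nM.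

Within the data shown here, the one step that can be read as a single change is a 6.7-fold lower number from compound 1 to compound 2 (0.83 log units; beyond the scatter). It shows that a larger saturated group on that nitrogen went with a lower number.

Compound 4 `CC(C)c1onc(-c2c(Cl)cccc2Cl)c1COc1ccc(-c2nc3ccc(C(=O)O)cc3n2-c2ccc(F)cc2)cc1` has not yet been measured. It differs from compound 2 in one place: 4-fluorophenyl in place of neopentyl on an aromatic nitrogen. Among the measured compounds shown here, no measured pair here exchanges a saturated chain for an aromatic ring at that position, so the step from compound 1 to compound 2 is the only guide, and it speaks only to size, not to flatness or to the fluorine. A change of this kind could therefore go either way. Weighing the favourable direction of a 6.7-fold lower number from compound 1 to compound 2 (0.83 log units; beyond the scatter) against the lack of any direct precedent, compound 4 is expected to land near compound 2, with an expected step of a 1.7-fold higher number from compound 2 to compound 4 (0.24 log units; within the scatter). The estimate for compound 4 is 1500 nM, with a range from 400 nM to 6000 nM.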

Compound 4, half-maximal inhibitory concentration: 2410 nM
Compound 4: the middle estimate sits 1.6-fold (0.21 log units) below what was measured; measured number inside the range.
By their numbers in this assay, from the lowest: compound 2; then compound 4; then compound 1. At a limit, above all of these: compound 3.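

Placing an aromatic ring on this nitrogen was a kind of change the earlier compounds did not cover, and the result shows that such a ring leaves a measurable inhibitor. Putting 4-fluorophenyl in place of neopentyl gives a 2.8-fold higher number from compound 2 to compound 4 (0.45 log units; beyond the scatter), so the aromatic ring does not match neopentyl, although the step is modest. Putting the same ring in place of ethyl gives a 2.4-fold lower number from compound 1 to compound 4 (0.38 log units; beyond the scatter), which places 4-fluorophenyl between the two saturated groups and qualifies the earlier picture in which a larger group went with a lower number: compound 4 carries more heavy atoms on this nitrogen than compound 2, yet compound 2 keeps the lower number.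

Nothing shown here gives a reason for this order of the three groups. From the compounds shown here alone, it also remains open what the fluorine contributes and whether the ring or its aromatic character matters, questions that plain phenyl, cyclohexyl or a pyridine ring on this nitrogen would begin to separate.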